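The source may report more compounds than this note shows. Statements on the series, on what has been measured and on what is new or still open speak of the compounds shown alone.

Of the compounds shown here, two on a shared core have been measured in an ADME assay on CHO cells (Cricetulus griseus) for inhibition, read by MTT assay; on this read-out higher numbers stand for weaker inhibition and lower numbers for stronger inhibition. Compound 1 `CCN(CC)Cc1cc(C)cc(Nc2nc3ccccc3n2Cc2ccc(C#N)cc2)c1O` gives 14200 nM. Compound 2 `CCN(CC)Cc1cc(Cl)cc(Nc2nc3ccccc3n2Cc2ccc(C(F)(F)F)cc2)c1O` gives > 50000 nM, which is a limit of this assay and not a number, so it has no exact place on the scale.

Compound 3 `CCN(CC)Cc1cc(C)cc(Nc2nc3ccccc3n2Cc2ccc(C(F)(F)F)cc2)c1O` has yet to be measured. It differs from compound 2 by methyl in place of chloro on an aromatic carbon, para to a hydroxy group: methyl in place of chloro on an aromatic carbon. Going by the values given here, no measured pair isolates this change. Compound 1 carries the same methyl, but with a nitrile where compound 3 has trifluoromethyl, and compound 1 gives 14200 nM. On that single reference, a move towards stronger inhibition in this assay is expected, though the reading could stay at the limit. The expected change is an at least 1.8-fold lower number from compound 2 to compound 3 (0.26 log units; that floor lies within the scatter). For compound 3 the estimated value is 27000 nM, with an expected range of 11000 nM to 50000 nM.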

Compound 3, half-maximal inhibitory concentration: 29300 nM
For compound 3 the middle estimate is 1.1-fold (0.04 log units) below the measured one; the range from low to high includes it.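

In this assay, methyl in place of chloro para to a hydroxy group turns a reading at the limit into a measured value, giving an at least 1.7-fold lower number from compound 2 to compound 3 (0.23 log units; that floor lies within the scatter). The size of this change can be given only as a floor, since compound 2 sits at a limit of the assay and not at a number: the limit of > 50000 nM in this assay, at which 1 of the 3 values shown sits. With the methyl held fixed, trifluoromethyl in place of cyano gives a 2.1-fold higher number from compound 1 to compound 3 (0.31 log units; beyond the scatter), a modest step, and the first on the shared core between two exact numbers.

The compounds shown leave open how far chloro and methyl actually differ at this position, and whether that difference would hold with a nitrile in place of the trifluoromethyl. They also leave open how a methoxy group, an amine or a longer chain at this position would read in this assay.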